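This account rests on a few compounds, and the source may have more. Where it says the series, first, only, none or still open, it means among the compounds named here.

Working notes on the series in a functional assay (aorta) with Rattus norvegicus as the target; on this read-out higher numbers stand for an effect only at larger amounts of compound and lower numbers for an effect already at smaller amounts. Compound 1 (`COc1ccc(-c2nc(N=C(N)N)sc2-c2ccc(OC)cc2)cc1`) gives 2 uM, compound 2 (`COc1ccc(-c2nc(CNC(=O)CSC)sc2-c2ccc(OC)cc2)cc1`) gives 6 uM and compound 3 (`CCN(CC)C(=O)c1nc(-c2ccc(OC)cc2)c(-c2ccc(OC)cc2)s1`) gives 14 uM. Compound 3 therefore has the highest number of the three, with both gaps beyond the scatter.

The next compound is compound 4 (`COc1ccc(-c2nc(C(=O)N3CCNC(CCO)C3)sc2-c2ccc(OC)cc2)cc1`), which keeps the shared core and the carbonyl. Its change from compound 3 is 3-(2-hydroxyethyl)piperazin-1-yl in place of diethylamino on a carbonyl carbon. In words, this is 3-(2-hydroxyethyl)piperazin-1-yl in place of diethylamino on a carbonyl carbon.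

For the measured compounds named here, no measured step makes this exact change, so the evidence is indirect. The closest steps are those that replace the group on the same aromatic carbon of the core: a 2.3-fold higher number from compound 2 to compound 3 (0.37 log units; beyond the scatter), a 3.0-fold higher number from compound 1 to compound 2 (0.48 log units; beyond the scatter) and a 7.0-fold higher number from compound 1 to compound 3 (0.85 log units; beyond the scatter). All three are modest, though beyond the scatter. Since compound 3 lies at the top of this small range at 14 uM, and the other two groups measured so far give lower numbers, a modest step to a lower number is expected in this assay. Going by the values given here, the data hold no direct precedent for this group, so the range stays wide.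

The expected step is a 2.3-fold lower number from compound 3 to compound 4 (0.37 log units; beyond the scatter).

For compound 4 the estimated value is 6 uM, with an expected range from 2 uM to 20 uM.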

Compound 4, concentration for half-maximal effect: 9.5 uM
The estimate for compound 4 lay 1.6-fold (0.20 log units) below the measured number; the measured number falls inside the stated range.
By their numbers in this assay, from the lowest: compound 1; then compounds 2, 4 and 3 (each within the scatter of the next, the first and the last beyond it).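

In this assay, the exchange on the carbonyl carbon gives a 1.5-fold lower number from compound 3 to compound 4 (0.17 log units; within the scatter), so this step stays within the scatter. This is the first change shown that keeps the carbonyl and alters only the amine attached to it, whereas the earlier steps all replaced the whole group on the aromatic carbon and all lay beyond the scatter. Here, a larger group with a six-membered non-aromatic ring and hydrogen-bond donors and acceptors replaces an open-chain group with neither donors nor acceptors, and the read-out does not move beyond the scatter; the data offer no evidence on why this exchange leaves the number where it is.

Going by these compounds, with only two amides on this carbonyl carbon, it remains open whether the ring and the 2-hydroxyethyl chain each leave the read-out unmoved or whether their contributions offset each other, which an unsubstituted piperazin-1-yl would help to separate. On these data alone, it is also open whether a carboxylic acid on the chain or a morpholine ring in the same place would shift the number beyond the scatter.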